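This account rests on a few compounds, and the source may have more. Where it says the series, first, only, none or still open, it means among the compounds named here.

Compound 1 `Cc1ccnc(/C(N)=N/NC(=S)N2CCOCC2)c1`: 86% in a functional assay on A-375 cells (Homo sapiens) for cytotoxicity, read by MTT assay, with a stated time of 72 h, tested at 10 uM; a higher number here means more inhibition of growth at the concentration tested, a lower number less inhibition of growth
Compound 2 `Cc1cccc(/C(N)=N/NC(=S)N2CCSCC2)n1`: 62.6%
Compound 3 `N/C(=N\NC(=S)N1CCSCC1)c1ccccn1`: 83.9%

Compound 2 stands lowest of the three numbers; the step of a number 21.3 percentage points higher from compound 2 to compound 3 (beyond the scatter) lies beyond the scatter, and compound 1 also gives a higher number than compound 2. Compound 4 `Cc1cccc(/C(N)=N/NC(=S)N2CCCC2)n1` differs from compound 2 by pyrrolidin-1-yl in place of thiomorpholin-4-yl on a thiocarbonyl carbon. Among the compounds with values here, no measured step concerns this ring exchange: the single step from a methyl-bearing to a methyl-free compound changes something else, and compounds 1 and 3 differ from each other in two places, so their gap cannot be split. Within the data shown here, with no comparable step at hand, a change beyond the scatter is not expected in this assay, and the range is kept wide. Compound 4 is therefore estimated at 63%, between 40% and 85%, an expected step of a number 0.4 percentage points higher from compound 2 to compound 4 (within the scatter).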

Compound 4, percent growth inhibition at one concentration: 55.9%
Compound 4: middle estimate off by 7.1 percentage points, on the high side; the measured number falls inside the stated range.
By their numbers in this assay, from the lowest: compounds 4 and 2 (each within the scatter of the next); then compounds 3 and 1 (each within the scatter of the next).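

On the thiocarbonyl carbon, pyrrolidin-1-yl in place of thiomorpholin-4-yl gives a number 6.7 percentage points lower from compound 2 to compound 4 (within the scatter) in this assay. Within the data shown here, this is the only single-place comparison at this position so far, and it shows that a five-membered ring without sulfur can replace the six-membered ring with two hetero atoms without a change beyond the scatter. No available evidence bears on this result. Still open, as far as these compounds go, is whether an open-chain dimethylamino group or a piperazin-1-yl ring on this carbon would keep the number, and whether the same ring exchange would hold on the methyl-free compound 3.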